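The source may hold more compounds than are shown below. What is called first, only, known or untested is meant among the compounds shown, and "the series" means these compounds.

Measured in an ADME assay on MRC5 cells (Homo sapiens) for cytotoxicity, read by MTT assay, with a stated time of 72 h; on this read-out lower numbers stand for higher toxicity in this test and higher numbers for lower toxicity in this test:
- Compound 1 `OC[C@H]1O[C@@H](n2cc(Cl)c3c(-c4ccccc4)ncnc32)[C@H](O)[C@@H]1O`: > 50000 nM, a limit of the assay
- Compound 2 `OC[C@H]1O[C@@H](n2cc(Cl)c3c(-c4ccoc4)ncnc32)[C@H](O)[C@@H]1O`: > 50000 nM, a limit of the assay

Compound 2 stands at the limit of > 50000 nM in this assay, at which 2 of the 2 values shown sit. Compound 3 `OC[C@H]1O[C@@H](n2cc(Cl)c3c(-c4cccs4)ncnc32)[C@H](O)[C@@H]1O` has thiophen-2-yl in place of furan-3-yl on an aromatic carbon of the shared core: thiophen-2-yl in place of furan-3-yl on an aromatic carbon. Going by the values given here, one measured step bears on this change, a step that the two limits leave unreadable from compound 1 to compound 2, where furan-3-yl took the place of phenyl on an aromatic carbon. That step gives no size to carry forward, and it shows no toxicity appearing in this assay with either ring. From the compounds shown here alone, the expectation is therefore for no clear change, though a lower number cannot be ruled out, since the true value of compound 2 is unknown. The estimate amounts to an at least 1.4-fold lower number from compound 2 to compound 3 (0.15 log units; that floor lies within the scatter), an expected step with no firm size. For compound 3 the expected value is 35000 nM, with an estimated range from 5000 nM to 50000 nM.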

Compound 3, half-maximal cytotoxic concentration: > 50000 nM
Compound 3: no number, only a limit; the forecaster's own chance of this, stated with the estimate: 60%; at least 1.4-fold (0.15 log units) between middle value and limit.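

No new step can be read among compound 1, compound 2 and compound 3, as all three give only a limit, not a number: the limit of > 50000 nM in this assay, at which 3 of the 3 values shown sit.

The compounds shown leave open whether phenyl, furan-3-yl and thiophen-2-yl differ at all in toxicity in this test.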